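This account rests on a few compounds, and the source may have more. Where it says the series, first, only, none or still open, it means among the compounds named here.

Compound 1 `CNC(=O)c1cc(Oc2ccc3nc(Nc4ccccc4)ncc3c2)ccn1` was examined in an ADME assay on Caco-2 cells (Homo sapiens) for permeability, in the apical to basolateral direction; on this read-out higher numbers stand for higher permeability and lower numbers for lower permeability. In this assay compound 1 gives < 1 10^-6 cm/s, which is a limit of the assay rather than a measured number. Compound 2 `CNC(=O)c1cc(Oc2ccc3nc(Nc4cccc(C(C)(C)C)c4)ccc3c2)ccn1` in this assay gives < 1 10^-6 cm/s, again a limit. Compound 3 `CNC(=O)c1cc(Oc2ccc3nc(Nc4cccc(C(C)(C)C)c4)cnc3c2)ccn1` in this assay gives < 1 10^-6 cm/s, also a limit. Taken together the three compounds show only (the limit of < 1 10^-6 cm/s in this assay, at which 3 of the 3 values shown sit), and since no two of them differ from each other in a single place, no measured step can be read from them.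

Compound 4 `CNC(=O)c1cc(Oc2ccc3nc(Nc4ccccc4Oc4ccccc4)ncc3c2)ccn1` has not yet been measured. It differs from compound 1 by phenoxy in place of hydrogen on an aromatic carbon, ortho to a large group. Among the measured compounds shown here, no measured pair shows what such a change does in this assay, so the expectation rests on the change itself. The expected step, an at least 3.0-fold higher number from compound 1 to compound 4 (0.47 log units; beyond the scatter), is an increase beyond the scatter, its size uncertain because the starting point of compound 1 is only a limit. Compound 4 is estimated at 3 10^-6 cm/s, with a range from 0.7 10^-6 cm/s to 12 10^-6 cm/s.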

Compound 4, apparent permeability: < 1 10^-6 cm/s
Compound 4: no number, only a limit; the forecaster's own chance of this, stated with the estimate: 35%; middle value at least 3.0-fold (0.47 log units) away from the limit.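

Compound 1 and compound 4 both give only a limit in this assay, so no step between them can be read: the limit of < 1 10^-6 cm/s in this assay, at which 4 of the 4 values shown sit.

The compounds shown leave open what number lies behind each limit, and so what phenoxy in place of hydrogen on an aromatic carbon does to this read-out.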